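This account rests on a few compounds, and the source may have more. Where it says the series, first, only, none or still open, it means among the compounds named here.

Measured in an assay on HEK293 cells for inhibition of acid ceramidase (Rattus norvegicus), read by LC-MS, with a stated time of 30 min; a higher number here means a weaker inhibitor, a lower number a stronger inhibitor:
compound 1, `CCCCCCNC(=O)n1cc(F)c(=O)n(C)c1=O`: 13 nM
compound 2, `CCCCCCNC(=O)n1cc(F)c(=O)n(CC)c1=O`: 18 nM
compound 3, `CCCCCCNC(=O)n1cc(F)c(=O)n(CC2CC2)c1=O`: 61 nM

Compound 3 carries the highest number of the three in this assay. The step of a 4.7-fold higher number from compound 1 to compound 3 (0.67 log units; beyond the scatter) and the step of a 3.4-fold higher number from compound 2 to compound 3 (0.53 log units; beyond the scatter) both lie beyond the scatter, whereas the step of a 1.4-fold higher number from compound 1 to compound 2 (0.14 log units; within the scatter) does not; so the cyclopropylmethyl group on the ring nitrogen stands apart from methyl and ethyl, with those two not separable from each other.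

Compound 4, `CCCCCCNC(=O)n1cc(F)c(=O)n(C(=O)C(C)C)c1=O`, is obtained from compound 3 by the change (isopropylcarbonyl in place of cyclopropylmethyl on an aromatic nitrogen). None of the three measured steps exchanges a saturated chain for a carbonyl-bearing group on that nitrogen, so none bears directly on this change. What they do show is that the three measured groups on that nitrogen, methyl, ethyl and cyclopropylmethyl, span only a modest range in this assay, with the largest difference being a 4.7-fold higher number from compound 1 to compound 3 (0.67 log units; beyond the scatter). On that basis compound 4 is expected to remain within the same range, and its step of a 1.5-fold lower number from compound 3 to compound 4 (0.18 log units; within the scatter) is expected to fall within the scatter rather than beyond it. The estimate for compound 4 in this assay is 40 nM, with a range from 10 nM to 160 nM.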

Compound 4, half-maximal inhibitory concentration: 21 nM
Beside the measured number, compound 4's estimate is 1.9-fold (0.28 log units) above it; measured number inside the range.
By their numbers in this assay, from the lowest: compounds 1, 2 and 4 (each within the scatter of the next); then compound 3.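

In this assay, a carbonyl-bearing group on that aromatic nitrogen is not set apart from the small saturated chains: the isopropylcarbonyl group cannot be separated from ethyl (a 1.2-fold higher number from compound 2 to compound 4 (0.07 log units; within the scatter)) or from methyl (a 1.6-fold higher number from compound 1 to compound 4 (0.21 log units; within the scatter)). For the compounds shown here, the step away from cyclopropylmethyl is different (a 2.9-fold lower number from compound 3 to compound 4 (0.46 log units; beyond the scatter)), so cyclopropylmethyl is now the only one of the four groups that stands apart, and compound 3 is the weakest inhibitor of the four, with steps to each of the others beyond the scatter. Nothing measured on these compounds explains why cyclopropylmethyl differs from the other three groups.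

The compounds shown do not separate the carbonyl from the branching in isopropylcarbonyl, which an isobutyl group on the same nitrogen would help to do, and they leave open how an amine, a carboxylic acid or a longer chain would fare there. As far as these compounds go, the fluoro group and the group of 9 heavy atoms are the same in all four compounds, so what either contributes also remains open.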